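This account rests on a few compounds, and the source may have more. Where it says the series, first, only, none or still open, it means among the compounds named here.

Compound 2 `COc1ccc(-c2cc3ccccc3nc2/C=C/C(=O)c2ccccn2)cc1` gives the lowest of the two numbers in a functional assay on SK-BR-3 cells (Homo sapiens) for antiproliferative activity, read by XTT assay, with a stated time of 72 h (on this read-out lower numbers stand for stronger inhibition and higher numbers for weaker inhibition), namely 370 nM; its nearest neighbour, compound 1 `COc1ccc(-c2cc3ccccc3nc2/C=C/C(=O)c2c(OC)cccc2OC)cc1`, gives 3830 nM, and the move a 10-fold lower number from compound 1 to compound 2 (1.01 log units; beyond the scatter) shows that the group on the carbonyl carbon matters strongly. Compound 3 `COc1ccc(-c2cc3ccccc3nc2/C=C/C(=O)c2ccc[nH]2)cc1` carries 1H-pyrrol-2-yl in place of pyridin-2-yl on a carbonyl carbon. Among the compounds with values here, only that one step touches this position, and it concerns a different group, so it sets no direct size for the new change. Compound 3 is therefore expected to give about 800 nM, between 200 nM and 3500 nM, an estimated step of a 2.2-fold higher number from compound 2 to compound 3 (0.33 log units; beyond the scatter) that may remain within the scatter.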

Compound 3, half-maximal inhibitory concentration: > 10000 nM
Compound 3: a limit, no number; the forecaster's own chance of this, stated with the estimate: 5%; at least 12-fold (1.09 log units) between middle value and limit.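

In this assay compound 3 gives a limit, not a number: the limit of > 10000 nM in this assay, at which 1 of the 3 values shown sits. The change to 1H-pyrrol-2-yl still brings an at least 27-fold higher number from compound 2 to compound 3 (1.43 log units; beyond the scatter), so a five-membered aromatic ring with a hydrogen-bond donor is far from equivalent to pyridin-2-yl at this position. It also gives an at least 2.6-fold higher number from compound 1 to compound 3 (0.41 log units; beyond the scatter), which makes compound 3 the weakest of the three and shows that a second heteroaryl group does not by itself keep the activity of compound 2. The compounds shown leave open whether ring size or the ring hydrogen on nitrogen accounts for this step. A 1-methylpyrrol-2-yl or a plain phenyl group on the carbonyl carbon would help separate the two.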